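The compounds below may be only part of what the source reports. "The series", "measured", "known", "first", "only" and "open" are said of these compounds alone.

Measured so far in a physicochemical assay for lipophilicity, at pH 7.4; a lower number here means a more polar compound, a higher number a more lipophilic compound:
Compound 1 `COC(c1cc(Cl)c2c(c1Cl)C(=O)N(Cc1c(C)cc(C)[nH]c1=O)CC2)C1CCOC1` gives 3; 3; 3; 3 (4 entries)
Compound 2 `Cc1cc(C)c(CN2CCc3c(Cl)cc([C@@H](CO)[C@@H]4CCOC4)c(Cl)c3C2=O)c(=O)[nH]1` gives 2

Compound 1 returned the same figure in all four of its readings. Compound 2 rests on a single reading, and in this assay compound 2 stands at 2 as the lower of the two. Compound 3 `Cc1cc(C)c(CN2CCc3c(Cl)cc([C@@H](CO)[C@@H]4CCCO4)c(Cl)c3C2=O)c(=O)[nH]1` has not yet been measured. Compared with compound 2, it carries oxolan-2-yl in place of oxolan-3-yl on a saturated chain carbon bound to an aromatic carbon and a saturated chain carbon. Among the compounds with values here, the two compounds have the same atoms, joined differently, and no measured pair here shows what such a change does. The expected step of a number 0.10 log units higher from compound 2 to compound 3 (within the scatter) is therefore small, with no shift beyond the usual scatter in either direction. Compound 3 is estimated at 2.1 (expected range 1.6 to 2.6).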

Compound 3, distribution coefficient: 2.1
Compound 3: middle estimate and measured number agree at the digits printed; measured number inside the range.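

In this assay, oxolan-2-yl in place of oxolan-3-yl on a saturated chain carbon bound to an aromatic carbon and a saturated chain carbon gives a number 0.10 log units higher from compound 2 to compound 3 (within the scatter). Within the data shown here, this pair is the first here to isolate a change in how the ring is joined at this position, with the atoms themselves unchanged, and the reading does not separate the two attachments. No available evidence bears on this result.

Going by these compounds, the two compounds carry only oxolanyl rings at this position, so the effect of a pyrrolidinyl amine, a cyclopentyl ring or a carboxylic acid there remains open. Whether any such group would shift the number beyond the scatter is left open too, as is whether repeated readings of compound 2 and compound 3 would hold.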